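The source may report more compounds than this note shows. Statements on the series, on what has been measured and on what is new or still open speak of the compounds shown alone.

Measured compounds in an assay on cells for positive allosteric modulation of Cystic fibrosis transmembrane conductance regulator variant F508del (Homo sapiens), with stated times of 10 min and 7 s, in the presence of a further agent that is not named here; a higher number here means that more compound is needed for the effect, a lower number that less compound is needed:
- compound 1 `CC1(C)Cc2c(sc(NC(=O)c3ccccc3O)c2C(N)=O)C(C)(C)O1`: 4 nM
- compound 2 `CC1(C)Cc2c(sc(NC(=O)c3cn[nH]c3)c2C(N)=O)C(C)(C)O1`: 125 nM
- compound 3 `CC1(C)Cc2c(sc(NC(=O)C3(O)CC3)c2C(N)=O)C(C)(C)O1`: 23 nM

Compound 3 holds the second highest of the three numbers in this assay. It sits between the other two: the step of a 5.8-fold higher number from compound 1 to compound 3 (0.76 log units; beyond the scatter) is modest, as is the step of a 5.4-fold lower number from compound 2 to compound 3 (0.74 log units; beyond the scatter). Only the group on the carbonyl carbon changes within this set, and every such change shifts the number beyond the scatter.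

Compound 4 `CC1(C)Cc2c(sc(NC(=O)C(C)(C)CO)c2C(N)=O)C(C)(C)O1` is not yet measured. The change from compound 3 is 1-(hydroxymethyl)-1-methylethyl in place of 1-hydroxycyclopropyl on a carbonyl carbon. Among the measured compounds shown here, no measured step makes this exact change. The two steps that involve the leaving group, a 5.8-fold higher number from compound 1 to compound 3 (0.76 log units; beyond the scatter) and a 5.4-fold lower number from compound 2 to compound 3 (0.74 log units; beyond the scatter), are the ones that bear on it, and both are of modest size. Since the donor and acceptor counts stay the same and only the ring is lost, a step at or slightly beyond the scatter, toward a higher number, seems most likely. Compound 4 is therefore expected to give about 40 nM, in a range from 12 nM to 130 nM, which would mean an estimated step of a 1.7-fold higher number from compound 3 to compound 4 (0.24 log units; within the scatter).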

Compound 4, half-maximal effective concentration: 75 nM
Beside the measured number, compound 4's estimate is 1.9-fold (0.27 log units) below it, within the range that was stated.
By their numbers in this assay, from the lowest: compound 1; then compound 3; then compounds 4 and 2 (each within the scatter of the next).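

In this assay, 1-(hydroxymethyl)-1-methylethyl in place of 1-hydroxycyclopropyl on the carbonyl carbon gives a 3.3-fold higher number from compound 3 to compound 4 (0.51 log units; beyond the scatter), although the hydrogen-bond donor and acceptor counts stay the same, so these counts alone do not fix the number at this position. The open-chain group also gives up the separation from the pyrazole seen with 1-hydroxycyclopropyl: a 1.7-fold lower number from compound 2 to compound 4 (0.22 log units; within the scatter), which leaves compound 2 and compound 4 unresolved, while 2-hydroxyphenyl keeps its clear lead with a 19-fold higher number from compound 1 to compound 4 (1.27 log units; beyond the scatter). The data shown offer no measurement that accounts for these steps.

Still open, from the compounds shown here alone, is whether a hydroxyl is needed at all, as an amine or a carboxylic acid on the cyclopropyl ring would test. A cyclobutyl ring carrying the hydroxyl, or a longer chain ending in one, would show how far the difference between compound 3 and compound 4 extends.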